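This account rests on a few compounds, and the source may have more. Where it says the series, first, only, none or still open, it means among the compounds named here.

Working notes on the benzyl ether series. In a functional assay on CHO-K1 cells for antagonist activity at prostaglandin E2 receptor EP1 subtype (Homo sapiens), read by FLIPR (a lower number here means a stronger inhibitor, a higher number a weaker inhibitor), compound 2 `Cc1cc(C(=O)O)nn1Cc1cc(Br)ccc1OCc1ccc(F)cc1` gives 11.8 nM, the lowest of the two numbers reported outright. Compound 3 `Cc1cc(C(=O)O)nn1Cc1cc(Br)ccc1OCc1ccc(C(F)(F)F)cc1` gives 97.7 nM in this assay, so that an 8.3-fold higher number from compound 2 to compound 3 (0.92 log units; beyond the scatter). For compound 1 `O=C(O)c1cnn(Cc2cc(Br)ccc2OCc2ccccc2)c1` this assay reports no number but only a limit, < 2000 nM; the set therefore contains (the limit of < 2000 nM in this assay, at which 1 of the 3 values shown sits).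

Compound 4 `Cc1cccc(COc2ccc(Br)cc2Cn2nc(C(=O)O)cc2C)c1` is not yet measured in this assay. It differs from compound 2 by 3-methylphenyl in place of 4-fluorophenyl on a saturated chain carbon bound to an oxygen on an aromatic ring. Going by the values given here, only one measured step touches the same benzyl ether, the one from compound 2 to compound 3, and that exchanged one group for another on the ring while keeping the group's name as given; compound 4 changes both the group and the name under which it sits. That step was modest but beyond the scatter, and it ran toward a higher number. The change to compound 4 is smaller in kind, a fluoro for a methyl, so a step in the same direction but of lesser size is expected, a 2.5-fold higher number from compound 2 to compound 4 (0.41 log units; beyond the scatter), with a fair chance that it stays within the scatter. Compound 4 is therefore estimated at 30 nM in this assay, in the range 8 nM to 120 nM.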

Compound 4, inhibition constant: 525 nM
The estimate for compound 4 lay 18-fold (1.24 log units) below the measured number; the measured number lies above the stated range.
By their numbers in this assay, from the lowest: compound 2; then compound 3; then compound 4.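

The aryl group on the saturated chain carbon bound to an oxygen on an aromatic ring proves far less forgiving than compound 3 alone suggested: in this assay, 3-methylphenyl in place of 4-fluorophenyl gives a 44-fold higher number from compound 2 to compound 4 (1.65 log units; beyond the scatter). Two replacements of the 4-fluorophenyl group now stand on the shared core, and both raise the number, with compound 3 at 97.7 nM and compound 4 at 525 nM, so neither group matches 4-fluorophenyl and the one with the same heavy-atom count as 4-fluorophenyl lies highest of the three. Nothing measured here offers a reason for the size of this step.

Compound 4 alters both the substituent and where it sits on the ring, so the compounds shown do not separate the loss of fluoro from the arrival of methyl at a different place. The 4-methylphenyl and 3-fluorophenyl groups on the core of compound 2 would each change only one of these, and a 4-chlorophenyl group would show whether a halogen in the place held by fluoro keeps the low number.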